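Swapping a Halogenated Ring in Two Growth Inhibitors

The source may report more compounds than this note shows. Statements on the series, on what has been measured and on what is new or still open speak of the compounds shown alone.

Compound 1 `O=C(/C(=C\c1ccc(O)c([N+](=O)[O-])c1)SCc1ccc(Br)cc1)c1ccc(Br)cc1` and compound 2 `O=C(/C(=C\c1ccc(O)c([N+](=O)[O-])c1)SCc1ccc(Br)cc1)c1ccc(Cl)cc1Cl` share one core. In a functional assay on DU-145 cells (Homo sapiens) for inhibition, read by trypan blue exclusion, with a stated time of 96 h (a lower number here means a stronger inhibitor of growth, a higher number a weaker inhibitor of growth), compound 1 gives 10000 nM and compound 2 gives 10000 nM; the change between them, (2,4-dichlorophenyl in place of 4-bromophenyl on a carbonyl carbon), brings no change at the digits printed from compound 1 to compound 2 (within the scatter). Compound 3 `O=C(/C(=C\c1ccc(Br)cc1)S(=O)(=O)c1ccc(Br)cc1)c1ccc(Br)cc1` is built on a different core, and the difference between the two cores is not broken down here. In this assay compound 3 gives 10000 nM. Compound 4 `O=C(/C(=C\c1ccc(Cl)cc1Cl)S(=O)(=O)c1ccc(Br)cc1)c1ccc(Br)cc1` arises from compound 3 by the same kind of change, 2,4-dichlorophenyl in place of 4-bromophenyl on a double-bonded chain carbon bound to a double-bonded chain carbon: here the entering ring sits on a double-bonded chain carbon bound to a double-bonded chain carbon, whereas in compound 2 it sits on a carbonyl carbon whose other neighbours are a double-bonded chain carbon. Because the like change gave no change at the digits printed from compound 1 to compound 2 (within the scatter), the step from compound 3 to compound 4 is estimated at no change at the digits printed from compound 3 to compound 4 (within the scatter). Compound 4 is expected to come out at about 10000 nM.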

Compound 4, concentration for 50% growth inhibition: 10000 nM
Beside the measured number, compound 4's estimate shows no gap at the digits printed; measured number inside the range.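

In this assay, putting 2,4-dichlorophenyl in place of 4-bromophenyl on a double-bonded chain carbon bound to a double-bonded chain carbon brings no change at the digits printed from compound 3 to compound 4 (within the scatter). Set beside the swap on a carbonyl carbon, the result carries over from one core to the other: the same change on two cores in this assay, no change at the digits printed (within the scatter) from compound 1 to compound 2 and no change at the digits printed (within the scatter) from compound 3 to compound 4, 1.0-fold (0.00 log units) apart, within the scatter of two such steps This shows agreement only for these two pairs, in which the swap moves nothing, and it does not show how the change would carry over to a core where it shifts the reading.

Still open, as far as these compounds go, is whether a ring bearing an amine or a carboxylic acid in place of the halogens would give a different reading on either core.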